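Benzofuran amide on the bis-indole core: an estimate

This account rests on a few compounds, and the source may have more. Where it says the series, first, only, none or still open, it means among the compounds named here.

Measured so far:
- compound 1 `CN1[C@@H]2c3[nH]c4ccccc4c3C[C@H]1[C@H](C#N)N1[C@@H](CNC(=O)c3ccc(F)cc3)c3[nH]c4ccccc4c3C[C@@H]21`: 310 nM
- compound 2 `CCc1ccc(C(=O)NC[C@H]2c3[nH]c4ccccc4c3C[C@H]3[C@H]4c5[nH]c6ccccc6c5C[C@@H]([C@H](C#N)N23)N4C)cc1`: 660 nM
- compound 3 `CN1[C@@H]2c3[nH]c4ccccc4c3C[C@H]1[C@H](C#N)N1[C@@H](CNC(=O)c3cccc4c3CCCC4)c3[nH]c4ccccc4c3C[C@@H]21`: 3540 nM

The three amides differ only in the group on the carbonyl carbon. In a functional assay on BGC-823 cells (Homo sapiens) for cytotoxicity, read by MTT assay, with a stated time of 72 h (a lower number here means a stronger inhibitor, a higher number a weaker inhibitor), compound 3 gives the highest number of the three: the step of an 11-fold higher number from compound 1 to compound 3 (1.06 log units; beyond the scatter) is large, and the step of a 5.4-fold higher number from compound 2 to compound 3 (0.73 log units; beyond the scatter) is modest but clearly beyond the scatter, while a 2.1-fold higher number from compound 1 to compound 2 (0.33 log units; beyond the scatter) is a modest shift within the pair of substituted phenyl rings.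

Compound 4 `CN1[C@@H]2c3[nH]c4ccccc4c3C[C@H]1[C@H](C#N)N1[C@@H](CNC(=O)c3cc4ccccc4o3)c3[nH]c4ccccc4c3C[C@@H]21` carries the change (1-benzofuran-2-yl in place of 1,2,3,4-tetrahydronaphthalen-5-yl on a carbonyl carbon). For the measured compounds named here, no measured step covers this exact swap. What the data show is that the two flat, single-ring amides sit well below compound 3, and the 1-benzofuran-2-yl group, being fully aromatic and one atom smaller, is closer in kind to those than to the partly saturated bicycle. A move back toward the range of compounds 1 and 2 is therefore expected, but with wide uncertainty. Compound 4 is estimated to show a 3.0-fold lower number from compound 3 to compound 4 (0.47 log units; beyond the scatter) in this assay, giving 1200 nM with a range of 350 nM to 4500 nM.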

Compound 4, half-maximal inhibitory concentration: 210 nM
Beside the measured number, compound 4's estimate is 5.7-fold (0.76 log units) above it; measured number below the stated range.
By their numbers in this assay, from the lowest: compounds 4 and 1 (each within the scatter of the next); then compound 2; then compound 3.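

In this assay the change to 1-benzofuran-2-yl gives a 17-fold lower number from compound 3 to compound 4 (1.23 log units; beyond the scatter) and so shows that two rings on the carbonyl carbon do not in themselves bring the high number of compound 3. The new group also goes beyond the 4-ethylphenyl amide with a 3.1-fold lower number from compound 2 to compound 4 (0.50 log units; beyond the scatter) and cannot be told apart from the 4-fluorophenyl amide with a 1.5-fold lower number from compound 1 to compound 4 (0.17 log units; within the scatter), so this position accepts a two-ring group as well as a single substituted phenyl ring. Nothing given here explains these differences.

As far as these compounds go, whether the ring oxygen of 1-benzofuran-2-yl matters stays open, and the 1-benzothiophen-2-yl amide, with sulfur in place of that oxygen, would test it. Also open, from the compounds shown here alone, is how an amine or a carboxylic acid on the benzofuran ring would behave at this position.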